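Nucleoside analogues and equilibrative nucleoside transporter 1 binding

The source may report more compounds than this note shows. Statements on the series, on what has been measured and on what is new or still open speak of the compounds shown alone.

Of the compounds shown here, two have been measured in an assay on isolated protein for binding affinity to Equilibrative nucleoside transporter 1 (Homo sapiens); a lower number here means a stronger inhibitor, a higher number a weaker inhibitor. Compound 1 `O=[N+]([O-])c1cccc2c1CN(c1ncnc3c1nc1n3[C@@H]3O[C@H](CO1)[C@@H](O)[C@H]3O)CC2` gives 1740000 nM. Compound 2 `OC[C@H]1O[C@@H](n2cnc3c(NCc4ccco4)ncnc32)[C@H](O)[C@@H]1O` gives 36300 nM, the lowest of the two numbers; the gap to compound 1 is beyond the scatter, so compound 2 is the stronger inhibitor of the pair. Within the data shown here, no step between measured compounds that differ in one place is available, so the series gives no measured step to lean on.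

Compound 3 `OC[C@H]1O[C@@H](n2cnc3c(SCC4CCCCC4)ncnc32)[C@H](O)[C@@H]1O` is not yet measured in this assay. It differs from compound 2 in one place: (cyclohexylmethyl)sulfanyl in place of ((furan-2-yl)methyl)amino on an aromatic carbon. Among the measured compounds shown here, no measured pair shows this change, so its effect is untested.

The expectation for compound 3 is a move toward a lower number in this assay, that is toward stronger inhibition, with the step from compound 2 to compound 3 estimated as a 120-fold lower number from compound 2 to compound 3 (2.08 log units; beyond the scatter). The estimate for compound 3 in this assay is 300 nM, with a range from 30 nM to 3000 nM, the wide range reflecting the absence of any measured step of this kind.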

Compound 3, half-maximal inhibitory concentration: 1550 nM
For compound 3 the middle estimate is 5.2-fold (0.71 log units) below the measured one; the measured number falls inside the stated range.
By their numbers in this assay, from the lowest: compound 3; then compound 2; then compound 1.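

In this assay, among these compounds, the first single-place change gives a 23-fold lower number from compound 2 to compound 3 (1.37 log units; beyond the scatter), a large step beyond the scatter, so the aromatic carbon carrying this group is a place where a substituent change can move the number strongly. The step also shows that neither the five-membered aromatic ring with its hetero atom nor the hydrogen-bond donor of ((furan-2-yl)methyl)amino is required for the lower number, since (cyclohexylmethyl)sulfanyl has a six-membered non-aromatic ring of carbon only and 0 hydrogen-bond donors. No measured data on hand account for the size of this step.

The ring and the atom joining it to the core change together in this single step, so the compounds shown leave open how much of the shift belongs to each. The (cyclohexylmethyl)amino and ((furan-2-yl)methyl)sulfanyl groups would divide the step between its two parts, while a longer chain between sulfur and the cyclohexyl ring would test whether the distance from the core also counts.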